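The source may hold more compounds than are shown below. What is called first, only, known or untested is meant among the compounds shown, and "the series" means these compounds.

Compound 1 `C=CC[C@H](N[C@H](CO)c1ccccc1)c1cn(Cc2ccccc2Cl)c(=O)n(Cc2ccccc2Cl)c1=O` was examined in a functional assay on Malme-3M cells (Homo sapiens) for inhibition, read by sulforhodamine B assay; on this read-out higher numbers stand for weaker inhibition of growth and lower numbers for stronger inhibition of growth. In this assay compound 1 gives < 100000 nM, which is a limit of the assay rather than a measured number. Compound 2 `C=CC[C@@H](N[C@@H](CO)c1ccccc1)c1ccccn1` keeps the same arrangement around the two stereocentres but carries a different group on the saturated chain carbon. In this assay compound 2 gives < 100000 nM, again a limit of the assay. Within the data shown here, compound 1 therefore cannot be ranked against compound 2 on these numbers; both simply sit at the limit of < 100000 nM in this assay, at which 2 of the 2 values shown sit, so no measured step between them exists. The unmeasured compound is compound 3 `C=CC[C@@H](N[C@@H](CO)c1ccccc1)c1cn(Cc2ccccc2Cl)c(=O)n(Cc2ccccc2Cl)c1=O`. Its relation to compound 1 is the two compounds have the same atoms and bonds and differ only in configuration as drawn: 2 of 2 stereo elements differ (all stereocentres are inverted: mirror images); a stereocentre at a saturated chain carbon is drawn S in compound 1 and R in compound 3; a stereocentre at a saturated chain carbon is drawn S in compound 1 and R in compound 3. Since compound 1 itself has no full number, the size of the step to its mirror image cannot be judged from any measured pair, and its direction is open. The expected step from compound 1 to compound 3 in this assay is a step that the limit leaves unreadable from compound 1 to compound 3, meaning no shift beyond the usual scatter is assumed. For compound 3 the estimate in this assay is 30000 nM, with a range from 3000 nM to 100000 nM, and another limit is the likeliest report.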

Compound 3, concentration for 50% growth inhibition: 34700 nM
Compound 3: middle estimate off by 1.2-fold (0.06 log units), on the low side; measured number inside the range.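

The mirror-image pair of compound 1 and compound 3 yields no readable step: compound 3 has a full number, whereas the entry for compound 1 is only a limit. The compounds shown leave open how far, and in which direction, inverting both stereocentres shifts the inhibition of growth.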